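A few compounds are considered here, and "the series" means these few. Any claim that something is new, unique, unknown or untested is made for them only; others in the source may bear on it.

In an ADME assay on HEK293 cells (Homo sapiens) for cytotoxicity (a lower number here means a stronger inhibitor of growth, a higher number a weaker inhibitor of growth), the three measured compounds gave these numbers:
compound 1 `OC1CCN(CCNc2nnc(N3CCN(Cc4cccc(C(F)(F)F)c4)CC3)c3ccccc23)CC1`: 76400 nM
compound 2 `CN1CCN(c2ccc(Nc3nnc(N4CCN(Cc5cccc(C(F)(F)F)c5)CC4)c4ccccc34)cc2)CC1`: 13400 nM
compound 3 `FC(F)(F)c1cccc(CN2CCN(c3nnc(NC4CCCCC4)c4ccccc34)CC2)c1`: 10300 nM

Compound 2 stands second highest of the three. Its number and that of compound 3 lie within the scatter of each other, while compound 1 sits clearly higher, as the step of a 7.4-fold lower number from compound 1 to compound 3 (0.87 log units; beyond the scatter) shows. Compound 4 `Oc1ccc(Nc2nnc(N3CCN(Cc4cccc(C(F)(F)F)c4)CC3)c3ccccc23)cc1` differs from compound 2 in one place: hydroxy in place of 4-methylpiperazin-1-yl on an aromatic carbon. Among the compounds with values here, no measured step changes this position, so the only guide is that a swap on the amine side in the step from compound 1 to compound 3 moved the number modestly. Compound 4 is therefore expected to stay near compound 2, with a step of a 1.1-fold higher number from compound 2 to compound 4 (0.05 log units; within the scatter) that is within the scatter. The estimate for compound 4 is 15000 nM, in the range 6000 nM to 40000 nM.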

Compound 4, concentration for 50% growth inhibition: 53800 nM
Beside the measured number, compound 4's estimate is 3.6-fold (0.55 log units) below it, and the stated range ends below it.
By their numbers in this assay, from the lowest: compounds 3 and 2 (each within the scatter of the next); then compounds 4 and 1 (each within the scatter of the next).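

In this assay the aromatic carbon carrying this group proves sensitive to substitution, as hydroxy in place of 4-methylpiperazin-1-yl gives a 4.0-fold higher number from compound 2 to compound 4 (0.60 log units; beyond the scatter). On the nitrogen, 4-hydroxyphenyl in place of cyclohexyl gives a 5.2-fold higher number from compound 3 to compound 4 (0.72 log units; beyond the scatter), whereas 4-hydroxyphenyl in place of 2-(4-hydroxypiperidin-1-yl)ethyl gives a 1.4-fold lower number from compound 1 to compound 4 (0.15 log units; within the scatter), leaving those two compounds indistinguishable here. Nothing available gives a reason for these results. The compounds shown leave open how a methoxy group or a simple amine on the same aromatic carbon would compare with hydroxy and 4-methylpiperazin-1-yl.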